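Working notes: methyl-to-hydrogen step from compound 2 to compound 4

The source may hold more compounds than are shown below. What is called first, only, known or untested is meant among the compounds shown, and "the series" means these compounds.

The set so far holds three measured compounds. Compound 1 `CCc1ccc(N(CC(C)C)S(=O)(=O)c2ccc3c(c2)C(O)CC(C2CCN(S(C)(=O)=O)CC2)O3)cc1` gives in a physicochemical assay for lipophilicity, at pH 7.4 (a lower number here means a more polar compound, a higher number a more lipophilic compound), a value of 3.22. Compound 2 `CCc1ccc(N(CC(C)C)S(=O)(=O)c2ccc3c(c2)C(O)CC(C(C)C2CCOCC2)O3)cc1` gives in this assay a value of 5.04, and compound 3 `CC(C)CN(c1ccc(C#N)cc1)S(=O)(=O)c1ccc2c(c1)C(O)CC(C1CCOCC1)O2` gives in this assay a value of 3.07. Compound 2 stands highest of the three; its nearest neighbour is compound 1, and the single listed step, a number 1.82 log units higher from compound 1 to compound 2 (beyond the scatter), is the only one that joins two of them through one change. Compound 3 differs from compound 2 in more than one place, so its value is noted only as a point of comparison, not as a step.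

Compound 4 `CCc1ccc(N(CC(C)C)S(=O)(=O)c2ccc3c(c2)C(O)CC(CC2CCOCC2)O3)cc1` is not yet measured. Against compound 2 the difference is hydrogen in place of methyl on a saturated chain carbon bound to two saturated ring carbons. Among the compounds with values here, this change is far smaller than the one from compound 1 to compound 2, which swapped a whole substituent; here only a methyl leaves and a hydrogen enters on the same saturated chain carbon bound to two saturated ring carbons. Within the data shown here, the relevant step is therefore the one from compound 1 to compound 2, which was large; the present change removes one carbon from the same region and is expected to move this assay in the opposite direction, by a modest amount that may or may not clear the scatter. Compound 4 is expected to come in at 4.6, within 4.2 to 5, so the estimated step is a number 0.44 log units lower from compound 2 to compound 4 (beyond the scatter).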

Compound 4, distribution coefficient: 4.44
Compound 4: middle estimate off by 0.16 log units, on the high side; the measured number falls inside the stated range.
By their numbers in this assay, from the lowest: compounds 3 and 1 (each within the scatter of the next); then compound 4; then compound 2.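

In this assay, within the data shown here, the hydrogen in place of methyl on a saturated chain carbon bound to two saturated ring carbons reads as a number 0.60 log units lower from compound 2 to compound 4 (beyond the scatter) and so gives the first one-place reading at this position, with the rest of the molecule unchanged. The earlier a number 1.82 log units higher from compound 1 to compound 2 (beyond the scatter) came from a whole-substituent exchange that carried this methyl with it, so the share of the methyl could not be separated from that of the rest of the substituent. With the methyl gone, (oxan-4-yl)methyl in place of 1-(methylsulfonyl)piperidin-4-yl on a saturated ring carbon still reads as a number 1.22 log units higher from compound 1 to compound 4 (beyond the scatter) and remains large, which leaves the greater part of the earlier gap with the exchange of substituent and a smaller part with the methyl.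

Where an ethyl group, a longer chain or an amine on the same saturated chain carbon would fall in this assay remains open, as does whether the methyl step would read the same on a core carrying a different sulfonamide aryl group. Nothing measured here accounts for the size of either step.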